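A few compounds are considered here, and "the series" means these few. Any claim that something is new, unique, unknown or untested is made for them only; others in the source may bear on it.

Working notes on the series. In an ADME assay on microsomes from liver (Homo sapiens) for metabolic stability, read by LC-MS, with a stated time of 30 min, tested at 1 uM (on this read-out lower numbers stand for a less stable compound and higher numbers for a more stable compound), compound 1 (`CC(C)(C)NCc1cc(Cl)cc(Nc2nc3cc(F)c(F)cc3n2Cc2ccc(C(F)(F)F)cc2)c1O`) gives 89% and compound 2 (`CC(C)(C)NCc1cc(Cl)cc(Nc2nc3ccccc3n2Cc2ccc(C(F)(F)F)cc2)c1O`) gives 81% as its reading. These two numbers lie within the scatter of each other, so compound 2 stands level with compound 1 and no order can be drawn between them. Both sit high on the read-out.

The next compound to read is compound 3 (`Cc1cc(CNC(C)(C)C)c(O)c(Nc2nc3ccccc3n2Cc2ccc(C(F)(F)F)cc2)c1`), which departs from compound 2 in one place: methyl in place of chloro on an aromatic carbon. This is methyl in place of chloro on an aromatic carbon, para to a hydroxy group and meta to a ((tert-butyl)amino)methyl group. The rest of the structure is unchanged.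

Within the data shown here, no measured pair shows this exchange, so the expectation has no direct precedent and the range is kept wide. The estimated step is a number 8 percentage points lower from compound 2 to compound 3 (within the scatter) in this assay as a modest fall, one that may not clear the scatter. For compound 3 the expected value is 73% with 58% to 88% as the estimated range.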

Compound 3, percent of the compound remaining: 99%
The estimate for compound 3 lay 26 percentage points below the measured number; the whole stated range lies below it.
By their numbers in this assay, from the lowest: compounds 2, 1 and 3 (each within the scatter of the next, the first and the last beyond it).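

In this assay the aromatic carbon para to a hydroxy group and meta to a ((tert-butyl)amino)methyl group now proves to be a place where the reading responds to a single exchange. Among these compounds, compounds 1 and 2 both carry chloro there and could say nothing about this position, whereas methyl in place of chloro gives a number 18 percentage points higher from compound 2 to compound 3 (beyond the scatter) as the only step that can be read across one change. The exchange keeps the count of heavy atoms at this carbon and adds no hydrogen-bond donor, acceptor or net charge, and no measurement in the series bears on why the reading moves with it.

What the compounds shown leave open is how other groups at this carbon would read, such as fluoro, methoxy, nitrile or an ethyl chain, so one exchange gives no trend across substituents. Going by these compounds, it also remains open whether methyl in place of chloro would give a similar step on the core of compound 1, which carries two fluoro groups.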